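A few compounds are considered here, and "the series" means these few. Any claim that something is new, unique, unknown or untested is made for them only; others in the source may bear on it.

Three compounds share one core and differ only in the group on the sulfonyl sulfur: compound 1 `Cn1c(=O)c(S(=O)(=O)c2ccc(F)cc2F)cc2cnc(Nc3cccc4[nH]ccc34)nc21`, compound 2 `Cn1c(=O)c(S(=O)(=O)c2ccc(F)cc2)cc2cnc(Nc3cccc4[nH]ccc34)nc21` and compound 3 `Cn1c(=O)c(S(=O)(=O)c2ccc(Cl)cc2)cc2cnc(Nc3cccc4[nH]ccc34)nc21`. In a functional assay on K562 cells (Homo sapiens) for inhibition, read by trypan blue exclusion, with a stated time of 72 h (a higher number here means a weaker inhibitor, a lower number a stronger inhibitor), compound 1 gives 1500 nM, compound 2 gives 750 nM and compound 3 gives 5000 nM. Compound 2 stands at the lowest of the three numbers, but the step of a 2.0-fold lower number from compound 1 to compound 2 (0.30 log units; within the scatter) is within the scatter, so nothing separates those two; the steps of a 6.7-fold higher number from compound 2 to compound 3 (0.82 log units; beyond the scatter) and a 3.3-fold higher number from compound 1 to compound 3 (0.52 log units; beyond the scatter) are beyond it. Compound 4 `Cn1c(=O)c(S(=O)(=O)c2ccc(F)cc2)cc2cnc(Nc3ccc4[nH]ccc4c3)nc21` differs from compound 2 in another part of the molecule: 1H-indol-5-yl in place of 1H-indol-4-yl on a nitrogen on an aromatic ring. For the measured compounds named here, none of the measured steps bears on that change, since all three alter the group on the sulfonyl sulfur and leave the group on the ring nitrogen untouched. With no guide in the data, one expects no step beyond the scatter, while allowing wider uncertainty than repeat error alone, so the expected step is a 1.3-fold higher number from compound 2 to compound 4 (0.12 log units; within the scatter). Compound 4 is therefore estimated at 1000 nM in this assay, within a range from 350 nM to 3000 nM.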

Compound 4, half-maximal inhibitory concentration: 200 nM
Compound 4: middle estimate off by 5.0-fold (0.70 log units), on the high side; the whole stated range lies above it.
By their numbers in this assay, from the lowest: compound 4; then compounds 2 and 1 (each within the scatter of the next); then compound 3.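

In this assay, for the compounds shown here, the amino nitrogen proves to be a position that responds to change, something the earlier compounds could not show, as all of them carried 1H-indol-4-yl there and varied only the group on the sulfonyl sulfur. The change gives a 3.8-fold lower number from compound 2 to compound 4 (0.57 log units; beyond the scatter), even though the two groups have the same atoms and the same counted features and differ only in how they are joined. The data shown offer no explanation for this step.

Still open, as far as these compounds go, is whether 1H-indol-5-yl has the same effect alongside the 2,4-difluorophenyl and 4-chlorophenyl groups on the sulfonyl sulfur. Also open, from the compounds shown here alone, is how other groups on that nitrogen, such as 1H-indol-6-yl, 1H-indazol-5-yl or a phenyl bearing a piperazine, would compare.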